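Thiourea and nitrophenyl return in the sulfonamide series

The compounds below may be only part of what the source reports. "The series", "measured", "known", "first", "only" and "open" are said of these compounds alone.

Compound 3 `Cc1cc(C)cc(NC(=O)NCCNS(=O)(=O)c2ccc(-c3ccccc3OCc3ccccc3)s2)c1` reaches only a limit in a functional assay on HeLa cells (Homo sapiens) for inhibition, read by CCK-8 assay, with a stated time of 48 h (on this read-out lower numbers stand for stronger inhibition and higher numbers for weaker inhibition), reported as > 50000 nM; the number itself is not known. Compound 1 `Nc1ccc(Oc2ccccc2-c2ccc(S(=O)(=O)NCCNC(=O)Nc3ccc(Cl)cc3)s2)cc1` likewise gives only the limit > 20000 nM in this assay. Compound 2 `O=S(=O)(NCCNC(=S)Nc1ccc(Cl)cc1)c1ccc(-c2ccccc2OCc2ccccc2)s1` gives 7000 nM in this assay. Going by the values given here, the single measured step bearing on the present change is an at least 7.1-fold higher number from compound 2 to compound 3 (0.85 log units; beyond the scatter), which moved from a thiourea to a urea. Compound 4 `O=[N+]([O-])c1ccc(NC(=S)NCCNS(=O)(=O)c2ccc(-c3ccccc3OCc3ccccc3)s2)cc1` differs from compound 3 by a group of 12 heavy atoms (7 carbon, 2 nitrogen, 2 oxygen, 1 sulfur; one six-membered aromatic ring of carbon only) in place of a group of 11 heavy atoms (9 carbon, 1 nitrogen, 1 oxygen; one six-membered aromatic ring of carbon only), on an amine nitrogen, so the thiourea of compound 2 comes back, carrying a nitro group instead of chlorine. Compound 2 with its thiourea gives 7000 nM in this assay, so a return toward that level is expected for compound 4, a step of an at least 6.2-fold lower number from compound 3 to compound 4 (0.79 log units; beyond the scatter). Compound 4 is estimated at 8000 nM, range 2500 nM to 40000 nM.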

Compound 4, half-maximal inhibitory concentration: 7100 nM
Estimate against measurement, compound 4: 1.1-fold (0.05 log units) above, and the stated range covers the measured number.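

With the thiourea kept, nitro in place of chloro on an aromatic carbon gives a 1.0-fold higher number from compound 2 to compound 4 (0.01 log units; within the scatter), so the two thioureas cannot be told apart in this assay. Against the urea, the entering thiourea group gives an at least 7.0-fold lower number from compound 3 to compound 4 (0.84 log units; beyond the scatter), which places compound 4 level with compound 2 rather than with compound 3. Compound 3 is a limit, so that step is a bound only: the limit of > 50000 nM in this assay, at which 1 of the 4 values shown sits.

Going by these compounds, compound 3 and compound 4 differ in both the thiourea and the aromatic substituents, so the share of each in that step stays open. Also open, on these data alone, is how a carboxylic acid or a nitrile would read on the same aromatic carbon.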